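The compounds below may be only part of what the source reports. "The series", "measured", "known", "first", "only" and "open" are said of these compounds alone.

Of the compounds shown here, two from this series have been measured so far. Compound 1 `CCOC(=O)C1=C(Nc2ccccc2)S/C(=C\c2ccccc2)C1=O` gives 29.6% in a functional assay on A549 cells (Homo sapiens) for inhibition, read by MTT assay, with a stated time of 72 h, tested at 10 uM; a higher number here means more inhibition at the concentration tested (going by the name of the read-out), a lower number less inhibition. Compound 2 `CCOC(=O)C1=C(Nc2ccccc2)S/C(=C\c2ccc[nH]2)C1=O` differs from it in one place and gives 23.5% in this assay; that change ran a number 6.1 percentage points lower from compound 1 to compound 2 (within the scatter), so the two numbers cannot be told apart. On the numbers shown, compound 2 therefore stands level with compound 1 rather than apart from it.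

Compound 3 `CCOC(=O)C1=C(Nc2ccc(CC)cc2)S/C(=C\c2ccc[nH]2)C1=O` has not yet been measured. It differs from compound 2 in one place: ethyl in place of hydrogen on an aromatic carbon. Going by the values given here, no measured step touches this part of the molecule; the only step seen so far, a number 6.1 percentage points lower from compound 1 to compound 2 (within the scatter), changed a different part of the molecule and stayed within the scatter. Nothing in the data therefore points to a step in this assay beyond the scatter, in either direction, and the expected step is a number 1.5 percentage points higher from compound 2 to compound 3 (within the scatter). Compound 3 is accordingly estimated at 25% in this assay, with a range expected to run from 8% to 42%.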

Compound 3, a percentage reported as inhibition, at one concentration (the size of the read-out at that concentration, not a potency): 17.5%
Beside the measured number, compound 3's estimate is 7.5 percentage points above it; low and high end bracket the measured number.
By their numbers in this assay, from the lowest: compounds 3, 2 and 1 (each within the scatter of the next, the first and the last beyond it).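

Going by these compounds alone, the phenyl group that stayed unchanged in the earlier compounds is touched here for the first time: in this assay, ethyl in place of hydrogen, para to a large group, gave a number 6 percentage points lower from compound 2 to compound 3 (within the scatter). This position therefore carries ethyl, a group of 2 carbons with no ring, without a shift that can be told from ordinary assay noise, so the two numbers stand level and neither compound can be ranked over the other. Nothing measured here bears on why the number came out this way.

On these data alone, one small group at one place says little about the position as a whole, so it remains open whether an amine, a carboxylic acid or a longer chain such as butyl on this same aromatic carbon would move the number beyond the scatter. It is also open whether ethyl at this place would behave the same way with the phenyl group of compound 1 in place of the 1H-pyrrol-2-yl group, since the compounds shown do not include that pairing.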